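The source may hold more compounds than are shown below. What is called first, only, known or untested is meant among the compounds shown, and "the series" means these compounds.

Working notes on the series. Compound 3 `COc1cccc(-c2ccc([C@H]3S[C@@H](C)C(=O)Nc4c3c(C)nn4-c3ccccc3C)cc2)c1` stands second highest of the three numbers in an assay on isolated protein for agonist activity at Bile acid receptor (Homo sapiens), read by AlphaScreen, with a stated time of 30 min (on this read-out higher numbers stand for larger maximal responses and lower numbers for smaller maximal responses), at 41%; its nearest neighbour is compound 1 `COc1ccccc1-n1nc(C)c2c1NC(=O)[C@H](C)S[C@@H]2c1ccc(Oc2ccccc2)cc1`, which gives 37% in this assay, a difference within the usual scatter, while compound 2 `CCc1ccccc1-n1nc(C)c2c1NC(=O)[C@H](C)S[C@@H]2c1ccc(Oc2ccccc2)cc1` is furthest at 190%, beyond the scatter. Going by the values given here, the only single-point step measured so far is a number 153 percentage points higher from compound 1 to compound 2 (beyond the scatter), and it lies on the aryl group carried by the ring nitrogen, not at the position now varied. Compound 4 `COc1ccc(Oc2ccc([C@H]3S[C@@H](C)C(=O)Nc4c3c(C)nn4-c3ccccc3C)cc2)cc1` is obtained from compound 3 by 4-methoxyphenoxy in place of 3-methoxyphenyl on an aromatic carbon. Among the compounds with values here, no measured pair isolates a change at this position: compound 1 and compound 2 both carry a phenoxy group there, but each differs from compound 3 in a second place as well, so their values only show that a phenoxy-bearing analogue may sit anywhere from the low to the high end of the range seen. A step of unknown direction, possibly beyond the scatter in either sense, is therefore expected in this assay. For compound 4 the efficacy is estimated at 70%, with a plausible range from 25% to 170%, which would correspond to an expected step of a number 29 percentage points higher from compound 3 to compound 4 (beyond the scatter).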

Compound 4, largest response reached (reported as efficacy), in percent of the reference or control that the assay uses: 70%
For compound 4 middle estimate and measured number coincide at the digits printed; the range from low to high includes it.
By their numbers in this assay, from the lowest: compounds 1 and 3 (each within the scatter of the next); then compound 4; then compound 2.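

In this assay, going by these compounds alone, the step at this position, a number 29 percentage points higher from compound 3 to compound 4 (beyond the scatter), shows for the first time that the response changes with the group on this aromatic carbon, para to a large group, while the rest of compound 3 stays unchanged. The exchange alters more than one feature at once: 8 heavy atoms with 1 hydrogen-bond acceptor leave, 9 heavy atoms with 2 hydrogen-bond acceptors enter, and the methoxy group changes its named place, so this single step cannot be assigned to any one of these features. No measurement given here bears on the cause of the step.

Still open, on these data alone, is which of these features carries the step, a question that plain phenoxy or 3-methoxyphenoxy on the core of compound 3 would help to separate. Also open, as far as these compounds go, are whether the step holds with the other aryl groups on the ring nitrogen, as in compound 1 and compound 2, and how an amine or a carboxylic acid in place of the methoxy group would read out in this assay.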